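Trading 3,4-dichlorophenyl for 4-bromophenyl

The source may report more compounds than this note shows. Statements on the series, on what has been measured and on what is new or still open speak of the compounds shown alone.

compound 1 `NC1=NC2(CCSCC2)N(OCCCOc2ccc(Cl)c(Cl)c2)C(N)=N1`: 1 nM
compound 2 `NC1=NC2(CCOCC2)N(OCCCOc2ccc(Cl)cc2)C(N)=N1`: 690 nM
compound 3 `NC1=NC2(CCOCC2)N(OCCCOc2ccc(Cl)c(Cl)c2)C(N)=N1`: 90 nM

These values all come from a functional assay on HCT-116 cells (Homo sapiens) for antiproliferative activity, read by MTT assay, with a stated time of 72 h; on this read-out higher numbers stand for weaker inhibition and lower numbers for stronger inhibition. Compound 3 stands in the middle of the three: at 90 nM it lies under compound 2 and well over compound 1. Compound 4 `NC1=NC2(CCOCC2)N(OCCCOc2ccc(Br)cc2)C(N)=N1` has not yet been measured. It carries 4-bromophenyl in place of 3,4-dichlorophenyl on an oxygen on a saturated carbon.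

For the measured compounds named here, one measured step bears on this change: a 7.7-fold lower number from compound 2 to compound 3 (0.88 log units; beyond the scatter), with chloro in place of hydrogen on an aromatic carbon. That step is modest but beyond the scatter. Compound 4 lacks the 3,4-dichlorophenyl group that this step produced, so a move in the opposite direction, toward a higher number, is expected. Going by the values given here, no measured compound carries bromo, so the expected move is somewhat smaller than that step and remains uncertain. The expected change is a 3.3-fold higher number from compound 3 to compound 4 (0.52 log units; beyond the scatter). Compound 4 is estimated at 300 nM, with an expected range of 100 nM to 800 nM.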

Compound 4, half-maximal inhibitory concentration: 320 nM
The estimate for compound 4 lay 1.1-fold (0.03 log units) below the measured number; the measured number falls inside the stated range.
By their numbers in this assay, from the lowest: compound 1; then compound 3; then compound 4; then compound 2.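

In this assay, 4-bromophenyl in place of 3,4-dichlorophenyl on an oxygen on a saturated carbon gives a 3.6-fold higher number from compound 3 to compound 4 (0.55 log units; beyond the scatter), so here the single bromo does not match what the two chloro groups achieve together. The earlier compounds shown here varied only the number of chloro groups on the aromatic ring, whereas the new result shows that the identity of the halogen also matters: bromo in place of chloro on an aromatic carbon gives a 2.2-fold lower number from compound 2 to compound 4 (0.33 log units; beyond the scatter). Nothing available explains either step.

From the compounds shown here alone, whether these steps would carry over to the core of compound 1 remains open. Also unresolved is how a methoxy group or an amine on the aromatic ring, or a longer chain leading to it, would compare.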